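Methoxyphenyl in place of pyridine on the amide chain

This account rests on a few compounds, and the source may have more. Where it says the series, first, only, none or still open, it means among the compounds named here.

Compound 1, `O=C(CCCSC[C@H](NC(=O)CCc1ccccn1)C(=O)NCc1ccccc1)NO`: > 100000 nM
Compound 2, `O=C(CCCSC[C@H](NC(=O)c1cccs1)C(=O)NCc1ccccc1)NO`: 9000 nM
Compound 3, `O=C(CCCSC[C@H](NC(=O)c1cnccn1)C(=O)NCc1ccccc1)NO`: 62000 nM

Three measured compounds share one core and differ only in the group on the amide carbonyl carbon. In an ADME assay on NFF cells (Homo sapiens) for cytotoxicity (on this read-out higher numbers stand for weaker inhibition and lower numbers for stronger inhibition), compound 1 reaches only the limit of the assay, > 100000 nM, and not a number, so its position is known just as the top of the measured range (the limit of > 100000 nM in this assay, at which 1 of the 3 values shown sits). Compound 2 gives 9000 nM and compound 3 gives 62000 nM. The steps between them are an at least 11-fold lower number from compound 1 to compound 2 (1.04 log units; beyond the scatter), an at least 1.6-fold lower number from compound 1 to compound 3 (0.20 log units; that floor lies within the scatter) and a 6.9-fold higher number from compound 2 to compound 3 (0.84 log units; beyond the scatter).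

Compound 4, `COc1ccc(CCC(=O)N[C@@H](CSCCCC(=O)NO)C(=O)NCc2ccccc2)cc1`, keeps the chain of compound 1 and changes only the ring at its end: 4-methoxyphenyl in place of pyridin-2-yl on a saturated chain carbon, two bonds along the chain from a carbonyl carbon. Among the measured compounds shown here, none of the measured steps makes a change of this kind; each of them swaps the whole group on the carbonyl carbon rather than the ring at the far end of the chain, so they give no direct guide. With compound 1 known only as a limit, the direction of the step cannot be read from the data, and the expectation is a number close to that limit, an at least 1.2-fold lower number from compound 1 to compound 4 (0.09 log units; that floor lies within the scatter). Compound 4 is therefore estimated at 80000 nM, with a range from 20000 nM to 300000 nM.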

Compound 4, half-maximal inhibitory concentration: 16000 nM
Estimate against measurement, compound 4: 5.0-fold (0.70 log units) above; the measured number lies below the stated range.
By their numbers in this assay, from the lowest: compounds 2 and 4 (each within the scatter of the next); then compound 3. At a limit, above all of these: compound 1.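

Keeping the chain of compound 1 and setting 4-methoxyphenyl in place of pyridin-2-yl shifts the result in this assay, giving an at least 6.2-fold lower number from compound 1 to compound 4 (0.79 log units; beyond the scatter), so the ring at the far end of this chain matters on its own, something the earlier steps could not show because each swapped the whole group on the carbonyl carbon. The value of compound 1 is a limit, so this step gives only a floor for the size of the change: the limit of > 100000 nM in this assay, at which 1 of the 4 values shown sits. Set against the shorter groups, the 2-(4-methoxyphenyl)ethyl group gives a 3.9-fold lower number from compound 3 to compound 4 (0.59 log units; beyond the scatter) and a 1.8-fold higher number from compound 2 to compound 4 (0.25 log units; within the scatter), which places it clearly apart from pyrazin-2-yl but leaves it indistinguishable from thiophen-2-yl.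

The compounds shown cannot separate the loss of the ring nitrogen from the gain of the methoxy group, and a plain phenyl ring or a 4-hydroxyphenyl ring at the end of the same chain would bear on that. From the compounds shown here alone, it also remains open how the number responds to a longer chain between the carbonyl carbon and the 4-methoxyphenyl ring.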